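A few compounds are considered here, and "the series" means these few. Any claim that something is new, unique, unknown or untested is made for them only; others in the source may bear on it.

Measured compounds:
Compound 1 `CCOC(=O)c1c(-c2cccc(Oc3ccccc3)c2)[nH]c2cc(OC)c(Cl)cc2c1=O`: > 21500 nM
Compound 2 `CCOC(=O)c1c(-c2cccc(Br)c2)[nH]c2cc(OC)c(Cl)cc2c1=O`: > 21500 nM
Compound 3 `CCOC(=O)c1c(-c2cc(F)cc(OC)c2)[nH]c2cc(OC)c(Cl)cc2c1=O`: > 21500 nM

The read-out here is an ADME assay on HepG2 cells (Homo sapiens) for cytotoxicity, read by luminescence, with a stated time of 72 h; on this read-out higher numbers stand for an effect only at larger amounts of compound and lower numbers for an effect already at smaller amounts. In this assay compound 2 gives > 21500 nM. That value is a limit of the assay and not a number, so compound 2 has no exact position, and the other two compounds also show only limits.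

Compound 4 `CCOC(=O)c1c(-c2cccc(Br)c2)[nH]c2cc(OC)c(F)cc2c1=O` has not been measured. It differs from compound 2 in one place: fluoro in place of chloro on an aromatic carbon. This is fluoro in place of chloro on an aromatic carbon, ortho to a methoxy group.

Among the compounds with values here, two measured steps bear on this only indirectly: a step that the two limits leave unreadable from compound 1 to compound 2 and a step that the two limits leave unreadable from compound 2 to compound 3. Neither has a readable size, and neither changes the chloro group. What they do show is the limit of > 21500 nM in this assay, at which 3 of the 3 values shown sit. With no sign of an effect among these three compounds, no step beyond the usual scatter is expected in this assay, in either direction. The expected step is a step that the limit leaves unreadable from compound 2 to compound 4.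

Another report of only a limit is the likeliest result. For compound 4 the estimated value is 25000 nM, with an expected range from 15000 nM to 50000 nM.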

Compound 4, half-maximal effective concentration: > 21500 nM
Compound 4: no number, only a limit; the forecaster's own chance of this, stated with the estimate: 85%; the middle value lies beyond the limit too.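

Compound 2 and compound 4 each give only a limit of the assay and not a number, so no step can be read between them. The compounds shown leave open at what concentration any of them would affect these cells, as all they share is one limit: the limit of > 21500 nM in this assay, at which 4 of the 4 values shown sit.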